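The source may hold more compounds than are shown below. What is called first, only, known or untested is meant among the compounds shown, and "the series" means these compounds.

In a functional assay on K562 cells (Homo sapiens) for cytotoxicity, read by MTT assay, with a stated time of 24 h (on this read-out lower numbers stand for stronger inhibition and higher numbers for weaker inhibition), three compounds sharing one core have been measured. Compound 1 `CN1C/C(=C\c2ccc(F)cc2)C(=O)/C(=C/c2cccc([N+](=O)[O-])c2)C1` gives 11300 nM. Compound 2 `CN1C/C(=C\c2ccc(Cl)cc2)C(=O)/C(=C/c2cccc([N+](=O)[O-])c2)C1` gives > 20000 nM, which is a limit of the assay and not a number. Compound 3 `CN1C/C(=C\c2ccc(C(F)(F)F)cc2)C(=O)/C(=C/c2cccc([N+](=O)[O-])c2)C1` gives 4780 nM, the lowest of the two actual numbers.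

Compound 4 `CN1C/C(=C\c2ccc(C#N)cc2)C(=O)/C(=C/c2ccc(C(F)(F)F)cc2)C1` is still unmeasured. It carries 4-cyanophenyl in place of 3-nitrophenyl on a double-bonded chain carbon bound to a double-bonded ring carbon.

Among the compounds with values here, the nearest evidence is indirect, since no measured step replaces 3-nitrophenyl. The two informative steps swap a different group: a 2.4-fold lower number from compound 1 to compound 3 (0.37 log units; beyond the scatter), and an at least 4.1-fold lower number from compound 2 to compound 3 (0.62 log units; beyond the scatter). They show that a single swap on this core can move the number beyond the scatter, but they give no direction for the new change. No clear shift is therefore expected, though the uncertainty is wide. The expected change is a 1.3-fold higher number from compound 3 to compound 4 (0.10 log units; within the scatter). For compound 4, the estimated value is 6000 nM, with an expected range of 1800 nM to 20000 nM.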

Compound 4, half-maximal inhibitory concentration: 4010 nM
Estimate against measurement, compound 4: 1.5-fold (0.18 log units) above, within the range that was stated.
By their numbers in this assay, from the lowest: compounds 4 and 3 (each within the scatter of the next); then compound 1. At a limit, above all of these: compound 2.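

In this assay, putting 4-cyanophenyl in place of 3-nitrophenyl gives a 1.2-fold lower number from compound 3 to compound 4 (0.08 log units; within the scatter), so the two groups cannot be told apart here. The earlier compounds shown here all carry 3-nitrophenyl and could not show this: on a double-bonded chain carbon bound to a double-bonded ring carbon, the nitro group is not required for a number at the level of compound 3. Nothing shown here accounts for why these two groups read alike.

This single swap leaves open how much change the position accepts, and whether a result like this would hold with the other aromatic group of compound 3 kept in place. An amine or a carboxylic acid on this aromatic ring, or a longer chain ending in that ring, would test the position further.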